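From 3,5-dichlorophenyl to 4-nitrophenyl in compound 3

This account rests on a few compounds, and the source may have more. Where it says the series, first, only, none or still open, it means among the compounds named here.

In a functional assay on RS4-11 cells (Homo sapiens) for inhibition, read by CCK-8 assay, with a stated time of 48 h (a lower number here means a stronger inhibitor, a higher number a weaker inhibitor), compound 1 (`Cc1cc(C)cc(NC(=O)NCCNS(=O)(=O)c2ccc(-c3ccccc3Oc3ccc([N+](=O)[O-])c([N+](=O)[O-])c3)s2)c1`) gives 3600 nM as its reading. Compound 2 (`O=C(NCCNS(=O)(=O)c1ccc(-c2ccccc2O[C@H]2CC[C@H](O)CC2)s1)Nc1ccc([N+](=O)[O-])cc1`), which also bears 4-nitrophenyl on an amide-type nitrogen, gives 4100 nM as its reading. Compound 3 (`O=C(NCCNS(=O)(=O)c1ccc(-c2ccccc2Oc2ccc([N+](=O)[O-])c([N+](=O)[O-])c2)s1)Nc1cc(Cl)cc(Cl)c1`) gives 2100 nM and so stands within the scatter of both. Compound 4 (`O=C(NCCNS(=O)(=O)c1ccc(-c2ccccc2Oc2ccc([N+](=O)[O-])c([N+](=O)[O-])c2)s1)Nc1ccc([N+](=O)[O-])cc1`) carries 4-nitrophenyl in place of 3,5-dichlorophenyl on an amide-type nitrogen. For the measured compounds named here, the one measured step at that nitrogen (a 1.7-fold lower number from compound 1 to compound 3 (0.23 log units; within the scatter)) also lies within the scatter. In this assay no step beyond the scatter is therefore expected, and the estimated step is a 1.4-fold higher number from compound 3 to compound 4 (0.15 log units; within the scatter) at most a small one. For compound 4 the estimated value is 3000 nM with an expected range of 1200 nM to 7000 nM around it.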

Compound 4, half-maximal inhibitory concentration: 3000 nM
For compound 4 middle estimate and measured number coincide at the digits printed; the range from low to high includes it.
By their numbers in this assay, from the lowest: compounds 3, 4, 1 and 2 (each within the scatter of the next).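

In this assay, the amide-type nitrogen now carries three different aryl groups with no separation beyond the scatter: 4-nitrophenyl in place of 3,5-dichlorophenyl gives (a 1.4-fold higher number from compound 3 to compound 4 (0.15 log units; within the scatter)), and in place of 3,5-dimethylphenyl gives (a 1.2-fold lower number from compound 1 to compound 4 (0.08 log units; within the scatter)). The oxygen on an aromatic ring also gets its first reading, as 3,4-dinitrophenyl in place of 4-hydroxycyclohexyl gives (a 1.4-fold lower number from compound 2 to compound 4 (0.14 log units; within the scatter)). No measured evidence bears on these results. Still open, on these data alone, is whether an amine or a carboxylic acid on the amide-type nitrogen would stay within this range, and whether a longer chain there would.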